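The source may hold more compounds than are shown below. What is called first, only, known or untested is meant among the compounds shown, and "the series" means these compounds.

Compound 1: `Cc1cccc(NC(=O)c2nn(C)c(OCC3CCCCC3)c2C)n1`, 1300 nM
Compound 2: `Cc1cccc(NC(=O)c2nc(C)n(-c3ccc(Cl)c(Cl)c3)c2C)n1`, 5.8 nM
Compound 3: `Cc1nc(C(=O)Nc2cccc(F)n2)c(C)n1-c1ccc(F)cc1`, 24.2 nM

Of the compounds shown here, three have been measured in a functional assay on HEK293 cells for negative allosteric modulation of metabotropic glutamate receptor 5 (Homo sapiens), read by FLIPR and calcium flux; a higher number here means a weaker inhibitor, a lower number a stronger inhibitor. Compound 1 gives 1300 nM, compound 2 gives 5.8 nM, and compound 3 gives 24.2 nM. Compound 3 thus stands second highest of the three numbers: its nearest neighbour is compound 2, whose number is lower by a margin beyond the scatter, and its furthest is compound 1, whose number is higher by a much wider margin.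

Compound 4, `Cc1nc(NC(=O)c2nc(C)n(-c3ccc(F)cc3)c2C)ccc1F`, has not yet been measured in this assay. It differs from compound 3 in one place: 5-fluoro-6-methylpyridin-2-yl in place of 6-fluoropyridin-2-yl on an amide-type nitrogen. For the measured compounds named here, compound 2 carries a 6-methylpyridin-2-yl on the same amide nitrogen and gives the lowest number of the three, but its core differs from that of compound 3 in another place as well, so no single step isolates the pyridine change. The step is therefore expected to be small, leaning toward a lower number, and may fall within the scatter. For compound 4 the estimate is 15 nM, with a range from 5 nM to 45 nM, which would mean a step of a 1.6-fold lower number from compound 3 to compound 4 (0.21 log units; within the scatter).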

Compound 4, half-maximal inhibitory concentration: 139 nM
Beside the measured number, compound 4's estimate is 9.3-fold (0.97 log units) below it; the whole stated range lies below it.
By their numbers in this assay, from the lowest: compound 2; then compound 3; then compound 4; then compound 1.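

In this assay, the change on the amide-type nitrogen from 6-fluoropyridin-2-yl to 5-fluoro-6-methylpyridin-2-yl gives a 5.7-fold higher number from compound 3 to compound 4 (0.76 log units; beyond the scatter), a step beyond the scatter and the first comparison among these compounds that isolates a single place. It shows that, with the rest of the molecule held constant, the number at this position responds to a change in the pyridine substituents, even though both groups have one six-membered aromatic ring and match in hydrogen-bond donors and acceptors. No independent data bear on why the number rises.

The compounds shown leave open which part of the change carries the step, as this single pair cannot separate the two parts of the substitution. A 5-fluoropyridin-2-yl or a 6-chloropyridin-2-yl on the same amide-type nitrogen would be needed to divide it.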